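Thiourea substitution on the ring amine of compound 1

The source may hold more compounds than are shown below. What is called first, only, known or untested is meant among the compounds shown, and "the series" means these compounds.

Compound 1 `NC(=O)c1c(NC(=O)c2ccccc2Cl)sc2c1CCNC2` is the unsubstituted secondary amine of the series. In a functional assay on HL-60 cells (Homo sapiens) for antiproliferative activity, with a stated time of 24 h (on this read-out lower numbers stand for stronger inhibition and higher numbers for weaker inhibition), compound 1 gives 18600 nM, and compound 2 `NC(=O)c1c(NC(=O)c2ccccc2Cl)sc2c1CCN(C(=S)Nc1ccccc1C(F)(F)F)C2` gives 10600 nM in this assay; these two values lie within the scatter of each other, so no ranking between them is claimed. Compound 3 `CSc1ccccc1NC(=S)N1CCc2c(sc(NC(=O)c3ccccc3Cl)c2C(N)=O)C1` carries a group of 11 heavy atoms (8 carbon, 1 nitrogen, 2 sulfur; one six-membered aromatic ring of carbon only) in place of a hydrogen atom, on an amine nitrogen in a ring. This change is expected to give a step no larger than the scatter, as the values of compound 1 and compound 2 suggest, so the expected step is a 1.7-fold lower number from compound 1 to compound 3 (0.23 log units; within the scatter). Compound 3 is estimated at 11000 nM in this assay, within 4000 nM to 30000 nM.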

Compound 3, half-maximal inhibitory concentration: 14600 nM
The estimate for compound 3 lay 1.3-fold (0.12 log units) below the measured number, and the stated range covers the measured number.
By their numbers in this assay, from the lowest: compounds 2, 3 and 1 (each within the scatter of the next).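

In this assay the methylsulfanyl-bearing thiourea on the ring amine nitrogen also stays within the scatter of the free amine (a 1.3-fold lower number from compound 1 to compound 3 (0.11 log units; within the scatter)), so a second substituent at this position gives no readable step. Methylsulfanyl in place of trifluoromethyl on an aromatic carbon (a 1.4-fold higher number from compound 2 to compound 3 (0.14 log units; within the scatter)) does not separate the two thioureas either. No further evidence bears on these results.

On these data alone, whether any substituent on this nitrogen can move the number beyond the scatter remains open. A urea, with oxygen in place of the thiourea sulfur, or a butyl chain in place of the aromatic ring would test this.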